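A Fluorophenyl Swap in a Series at the Limit

The compounds below may be only part of what the source reports. "The series", "measured", "known", "first", "only" and "open" are said of these compounds alone.

Going by the values given here, in a functional assay on K562 cells (Homo sapiens) for antiproliferative activity, read by MTT assay, with a stated time of 72 h (a higher number here means a weaker inhibitor, a lower number a stronger inhibitor), no compound of this small series has yet given a number. Compound 1 (`COc1cc(-c2ncnn2-c2cccc(F)c2)cc(OC)c1OC`) gives > 10000 nM as its result, which is a limit of the assay. Compound 2 (`COc1cc(-c2ncnn2-c2ccc(Cl)cc2Cl)cc(OC)c1OC`) gives > 10000 nM as its result, again a limit. Compound 3 (`COc1cc(-c2ncnn2-c2cccc(N)c2)cc(OC)c1OC`) gives > 10000 nM as its result, also a limit. Where compound 3 stands is therefore the limit of > 10000 nM in this assay, at which 3 of the 3 values shown sit, and no order can be drawn among the three.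

Compound 4 (`COc1cc(-c2ncnn2-c2ccc(F)cc2)cc(OC)c1OC`) carries 4-fluorophenyl in place of 3-aminophenyl on an aromatic nitrogen and keeps the rest of the core of compound 1. Among the compounds with values here, three measured steps bear on this place: a step that the two limits leave unreadable from compound 1 to compound 2 and a step that the two limits leave unreadable from compound 1 to compound 3 and a step that the two limits leave unreadable from compound 2 to compound 3 in turn. None of them has a readable size, so they offer no measured effect of changing this aryl group. Within the data shown here, the closest precedent is compound 1, a fluorophenyl compound with > 10000 nM as its limit. No step beyond the scatter is therefore expected, and the estimated move is a number no higher from compound 3 to compound 4 (the limit leaves the size open) in this assay with no direction that can be defended. Compound 4 is estimated at 10000 nM with an expected range from 3000 nM to 30000 nM and may well return only a limit.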

Compound 4, half-maximal inhibitory concentration: > 10000 nM
Compound 4: only a limit was reported; the forecaster's own chance of this, stated with the estimate: 75%; the middle value sits exactly at the limit.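

In this assay compound 4 gives > 10000 nM as its result, which is a limit. The steps to compound 4 from compound 1, compound 2 and compound 3 therefore cannot be read, and the series stays where it stood: the limit of > 10000 nM in this assay, at which 4 of the 4 values shown sit. The compounds shown leave open how these aryl groups on the shared core would rank against one another.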